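Swapping a side group for piperazin-1-yl in compound 3

This account rests on a few compounds, and the source may have more. Where it says the series, first, only, none or still open, it means among the compounds named here.

- Compound 1 `CCNc1nc(SCc2nc3ccccc3[nH]2)nc(-c2ccccc2)c1C#N` gives 5.3 nM
- Compound 2 `N#Cc1c(NNC(N)=S)nc(SCc2nc3ccccc3[nH]2)nc1-c1ccccc1` gives 3.2 nM

Both numbers come from a functional assay on SK-MEL-28 cells (Homo sapiens) for cytotoxicity, read by MTT assay, with a stated time of 3 days (on this read-out lower numbers stand for stronger inhibition and higher numbers for weaker inhibition), and lie within the usual scatter of each other, so compound 2 stands level with compound 1 and neither can be put ahead.

Compound 3 `N#Cc1c(-c2ccccc2)nc(SCc2nc3ccccc3[nH]2)nc1N1CCNCC1` has not yet been measured. It keeps the core of compound 2 and changes one group (a group of 6 heavy atoms (4 carbon, 2 nitrogen; one six-membered non-aromatic ring with 2 hetero atoms) in place of a group of 5 heavy atoms (1 carbon, 3 nitrogen, 1 sulfur; no ring), on an aromatic carbon). The piperazin-1-yl group enters on an aromatic carbon, ortho to a cyano group, so a ring now sits where neither measured compound has one.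

Within the data shown here, one measured step bears on this change (a 1.7-fold lower number from compound 1 to compound 2 (0.22 log units; within the scatter)). In it, a group of 2 heavy atoms gave way to a group of 4 heavy atoms on a nitrogen on an aromatic ring, and the number stayed within the scatter. A single step is thin evidence, and no ring has been tested at this place, so the range has to stay wide.

No step beyond the scatter is expected in this assay, and the estimated step is small (a 1.6-fold higher number from compound 2 to compound 3 (0.19 log units; within the scatter)). The estimate for compound 3 is 5 nM (expected range 1.5 nM to 18 nM).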

Compound 3, half-maximal inhibitory concentration: 2.6 nM
For compound 3 the middle estimate is 1.9-fold (0.28 log units) above the measured one; the range from low to high includes it.
By their numbers in this assay, from the lowest: compounds 3, 2 and 1 (each within the scatter of the next, the first and the last beyond it).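

In this assay, this position accepts a ring: piperazin-1-yl on the aromatic carbon ortho to a cyano group gives a 1.2-fold lower number from compound 2 to compound 3 (0.09 log units; within the scatter) and so stands level with the open-chain group of compound 2. Neither the loss of that chain's double bond nor the drop in hydrogen-bond donors counted under the change moves the number beyond the scatter. Against the smaller ethylamino group, the same ring gives a 2.0-fold lower number from compound 1 to compound 3 (0.31 log units; beyond the scatter) and is the only step among these three compounds to pass the scatter, though only modestly. Nothing measured here gives a reason for these numbers.

The compounds shown leave open whether the second ring nitrogen of piperazin-1-yl matters, a question that morpholin-4-yl or piperidin-1-yl at this place would address, as would a methyl group on that nitrogen. They also leave open how far the position tolerates larger groups, such as a benzyl group on the piperazine, and whether the phenyl group kept throughout can be changed without raising the number.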